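Compound 3: hydrogen in place of 4-methylphenyl

This account rests on a few compounds, and the source may have more. Where it says the series, first, only, none or still open, it means among the compounds named here.

Compound 1 (`CCN(CC)CN1C(=O)/C(=N/NC(=S)Nc2ccc(Cl)cc2)c2ccccc21`) and compound 2 (`CCN(CC)CN1C(=O)/C(=N/NC(=S)Nc2ccc(C)cc2)c2ccccc21`) share a core and differ only in methyl in place of chloro on an aromatic carbon. In an ADME assay on MDCK cells (Canis lupus familiaris) for cytotoxicity (a lower number here means that less compound is tolerated, a higher number that more compound is tolerated), compound 1 gives 400 nM, and compound 2 gives 200 nM. These two numbers lie within the scatter of each other, so compound 2 cannot be separated from compound 1.

Compound 3 (`CCN(CC)CN1C(=O)/C(=N/NC(N)=S)c2ccccc21`) departs further from compound 2: hydrogen in place of 4-methylphenyl on an amide-type nitrogen. In short, this is hydrogen in place of 4-methylphenyl on an amide-type nitrogen. Among the measured compounds shown here, the only measured step, a 2.0-fold lower number from compound 1 to compound 2 (0.30 log units; within the scatter), bears on this change only loosely, as it swaps a group on the aromatic ring and leaves the ring in place. For the measured compounds named here, no measured compound lacks that ring, so the size of the coming step cannot be read from the data. A higher number is a weak expectation, drawn from the size of the structural change alone, and a step beyond the scatter is possible. The expected step is a 4.0-fold higher number from compound 2 to compound 3 (0.60 log units; beyond the scatter), and this estimate carries a wide margin. For compound 3 the estimated value is 800 nM, with an expected range from 200 nM to 4000 nM.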

Compound 3, half-maximal cytotoxic concentration: 85800 nM
Estimate against measurement, compound 3: 110-fold (2.03 log units) below; the whole stated range lies below it.
By their numbers in this assay, from the lowest: compounds 2 and 1 (each within the scatter of the next); then compound 3.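

In this assay the amide-type nitrogen of the thiourea-like end proves to be a far more sensitive place than the aromatic ring substituent: hydrogen in place of 4-methylphenyl gives a 430-fold higher number from compound 2 to compound 3 (2.63 log units; beyond the scatter), and hydrogen in place of 4-chlorophenyl gives a 210-fold higher number from compound 1 to compound 3 (2.33 log units; beyond the scatter). Exchanging chloro for methyl on that ring gave only a 2.0-fold lower number from compound 1 to compound 2 (0.30 log units; within the scatter), so among these three compounds the presence or absence of the whole aryl group separates the numbers, while the two ring substituents compared do not. Nothing at hand explains the size of this step.

The compounds shown leave open whether the large step belongs to the aromatic ring as such or to any sizeable group on that nitrogen: a cyclohexyl group or a small methyl in place of the hydrogen would show whether the number stays near that of compound 3 or falls back towards those of compound 1 and compound 2. Also open, going by these compounds, is whether a different ring substituent, such as methoxy or a carboxylic acid, would move the number on the aryl-bearing side of the series.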